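Chloro in place of hydrogen on compound 1

The source may report more compounds than this note shows. Statements on the series, on what has been measured and on what is new or still open speak of the compounds shown alone.

In a functional assay on MCF7 cells (Homo sapiens) for cytotoxicity, read by sulforhodamine B assay, with a stated time of 48 h (on this read-out higher numbers stand for weaker inhibition and lower numbers for stronger inhibition), compound 1 (`C=CCOc1c(Cl)cccc1C(=O)c1cccnc1`) gives > 100000 nM as a limit of the assay and not a number. Compound 1 therefore stands at the limit of > 100000 nM in this assay, at which 1 of the 2 values shown sits, and has no exact position.

In this assay compound 2 (`O=C(c1cccnc1)c1cccc(Cl)c1O`) gives 26700 nM on the same scale. Among the compounds with values here, the one measured step is an at least 3.7-fold lower number from compound 1 to compound 2 (0.57 log units; beyond the scatter) for hydrogen in place of allyl on an oxygen on an aromatic ring.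

Compound 3 (`C=CCOc1c(Cl)cc(Cl)cc1C(=O)c1cccnc1`) differs from compound 1 by chloro in place of hydrogen on an aromatic carbon and keeps the allyloxy group. The new chloro sits para to that group. Within the data shown here, no measured step covers this change, so the step to compound 2 offers only weak guidance.

A small move toward lower numbers is expected, possibly none beyond the scatter, and a further limit is quite likely. The estimated result is an at least 1.6-fold lower number from compound 1 to compound 3 (0.22 log units; that floor lies within the scatter) in this comparison. For compound 3 the expected value is 60000 nM within an estimated range of 25000 nM to 100000 nM overall.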

Compound 3, half-maximal inhibitory concentration: 85000 nM
For compound 3 the middle estimate is 1.4-fold (0.15 log units) below the measured one; the range from low to high includes it.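

In this assay, with a chloro para to an allyloxy group and the allyloxy group still in place, compound 3 gives 85000 nM. The change itself comes to an at least 1.1-fold lower number from compound 1 to compound 3 (0.07 log units; that floor lies within the scatter), so only a floor is known, and no gain in potency can be claimed for this position. The true size of the step remains unknown because compound 1 gives a limit of the assay and not a number: the limit of > 100000 nM in this assay, at which 1 of the 3 values shown sits.

As far as these compounds go, whether this aromatic carbon accepts anything other than chloro, such as a methoxy group, an amine or a carboxylic acid, remains open. Also open, from the compounds shown here alone, is whether the same chloro would shift the value in compound 2, which has a hydrogen in place of the allyl.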